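Methyl on the Hydroxy Oxygen of Compound 1

A few compounds are considered here, and "the series" means these few. Any claim that something is new, unique, unknown or untested is made for them only; others in the source may bear on it.

Measured compounds:
compound 1 `O=C(Nc1cccc(-n2cc(-c3ccncc3)c(-c3ccc(Cl)c(O)c3)n2)c1)Nc1ccc(Cl)c(Cl)c1`, 6970 nM
compound 2 `COc1cc(-c2nn(-c3cccc(NC(=O)Nc4ccc(Cl)c(C(F)(F)F)c4)c3)cc2-c2ccncc2)ccc1Cl`, 3710 nM
compound 3 `COc1cc(-c2nn(-c3cccc(NC(=O)c4ccccc4)c3)cc2-c2ccncc2)ccc1Cl`, 12900 nM

In a functional assay on M14 cells (Homo sapiens) for inhibition, read by sulforhodamine B assay, with a stated time of 48 h (a higher number here means a weaker inhibitor of growth, a lower number a stronger inhibitor of growth), compound 1 gives 6970 nM, a number that lies between those of compound 2 and compound 3, with both gaps within the scatter. For the measured compounds named here, the one measured step, a 3.5-fold higher number from compound 2 to compound 3 (0.54 log units; beyond the scatter), changes the urea end of the molecule and does not touch the oxygen on the aromatic ring. Compound 4 `COc1cc(-c2nn(-c3cccc(NC(=O)Nc4ccc(Cl)c(Cl)c4)c3)cc2-c2ccncc2)ccc1Cl` differs from compound 1 by methyl in place of hydrogen on an oxygen on an aromatic ring. Going by the values given here, no measured pair tests this change, so nothing in the data points to a step beyond the scatter. Compound 2, which carries the methoxy group, gives 3710 nM, within the scatter of compound 1. Compound 4 is therefore expected to give 5000 nM, between 2000 nM and 14000 nM, meaning an expected 1.4-fold lower number from compound 1 to compound 4 (0.14 log units; within the scatter).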

Compound 4, concentration for total growth inhibition: 2690 nM
Estimate against measurement, compound 4: 1.9-fold (0.27 log units) above; low and high end bracket the measured number.
By their numbers in this assay, from the lowest: compounds 4, 2, 1 and 3 (each within the scatter of the next, the first and the last beyond it).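

Methyl on the oxygen of the 4-chloro-3-hydroxyphenyl group gives a 2.6-fold lower number from compound 1 to compound 4 (0.41 log units; beyond the scatter) in this assay and is the first measured step at this position. With the methoxy group held constant, (3,4-dichlorophenyl)amino in place of phenyl gives a 4.8-fold lower number from compound 3 to compound 4 (0.68 log units; beyond the scatter) and shows that the urea end still counts, while chloro in place of trifluoromethyl gives a 1.4-fold lower number from compound 2 to compound 4 (0.14 log units; within the scatter) and does not separate these two compounds. Nothing shown here accounts for the step at this oxygen. Going by these compounds, whether ethoxy or an amine at this position would behave like methoxy stays open, as does whether methyl gives a similar step with the end group of compound 3.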